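This account rests on a few compounds, and the source may have more. Where it says the series, first, only, none or still open, it means among the compounds named here.

Measured so far:
- compound 1 `COc1cc2nc(-c3ccc(Cl)cc3)cc(OCCCN3CCC(O)CC3)c2cc1OC`: 20%
- compound 2 `COc1cc2nc(-c3ccc(C(F)(F)F)cc3)cc(OCCCN3CCCCC3)c2cc1OC`: 20%

In an assay on isolated protein for inhibition of DNA topoisomerase 1 (Homo sapiens), with a stated time of 30 min, tested at 1 uM (a lower number here means less inhibition, a higher number more inhibition at the concentration tested (going by the name of the read-out)), compound 2 gives 20%, level with compound 1 at the digits printed, the two values lying within the scatter of each other. Compound 3 `COc1cc2nc(-c3ccc(C(F)(F)F)cc3)cc(OCCCN3CCC(O)CC3)c2cc1OC` differs from compound 2 by hydroxy in place of hydrogen on a saturated ring carbon. Compound 1 already carries this hydroxy group on its saturated ring, and with a different substituent on the aryl ring shows the same read-out as compound 2, so no step beyond the scatter is expected. Compound 3 is estimated at 20%, range 8% to 35%, a step of no change at the digits printed from compound 2 to compound 3 (within the scatter) expected.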

Compound 3, a percentage reported as inhibition, at one concentration (the size of the read-out at that concentration, not a potency): 0%
The estimate for compound 3 lay 20 percentage points above the measured number; the whole stated range lies above it.
By their numbers in this assay, from the lowest: compound 3; then compounds 1 and 2 (each within the scatter of the next).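

In this assay, going by these compounds alone, hydroxy in place of hydrogen on the saturated ring carbon comes with a number 20 percentage points lower from compound 2 to compound 3 (beyond the scatter), the first reading of this position with the aryl group held fixed. With 4-hydroxypiperidin-1-yl held fixed, trifluoromethyl in place of chloro on the aromatic carbon comes with a number 20 percentage points lower from compound 1 to compound 3 (beyond the scatter), so the aryl substituent also counts in this series. Nothing at hand explains either step.

The compounds shown leave open whether a methoxy group or an amine on the same ring carbon gives a similar step. They also leave open whether the hydroxy step recurs with chloro on the aromatic carbon.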